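This account rests on a few compounds, and the source may have more. Where it says the series, first, only, none or still open, it means among the compounds named here.

Compound 2 `CC(c1ccc(-c2ccccc2)c(F)c1)c1nnc2n1N=C(c1ccc(C(F)(F)F)cc1)CS2` gives 4300 nM in a functional assay on MCF7 cells (Homo sapiens) for inhibition, read by sulforhodamine B assay, with a stated time of 72 h (a lower number here means a stronger inhibitor, a higher number a weaker inhibitor), and compound 1 `CC(c1ccc(-c2ccccc2)c(F)c1)c1nnc2n1N=C(c1ccc(OC(F)(F)F)cc1)CS2` gives 4800 nM, the two within the scatter of one another, as the step of a 1.1-fold lower number from compound 1 to compound 2 (0.05 log units; within the scatter) shows. Compound 3 `COc1ccc(C2=Nn3c(nnc3C(C)c3ccc(-c4ccccc4)c(F)c3)SC2)cc1` carries methoxy in place of trifluoromethyl on an aromatic carbon. Within the data shown here, the one measured step that bears on this, the exchange of groups on an aromatic carbon, stayed within the scatter, and nothing measured covers methoxy. For compound 3 in this assay no step beyond the scatter is therefore expected, no change at the digits printed from compound 2 to compound 3 (within the scatter). Compound 3 is estimated at 4300 nM, with a range from 1500 nM to 12000 nM.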

Compound 3, half-maximal inhibitory concentration: 2600 nM
Compound 3: the middle estimate sits 1.7-fold (0.22 log units) above what was measured, and the stated range covers the measured number.
By their numbers in this assay, from the lowest: compounds 3, 2 and 1 (each within the scatter of the next).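

In this assay, among these compounds, methoxy is the first group at this position, on an aromatic carbon para to a large group, that carries no fluorine, and the number still does not leave the scatter: the readings are a 1.7-fold lower number from compound 2 to compound 3 (0.22 log units; within the scatter) and a 1.8-fold lower number from compound 1 to compound 3 (0.27 log units; within the scatter). The position has thus tolerated three groups, with and without fluorine, without a step beyond the scatter. Nothing available explains this result. From the compounds shown here alone, whether an amine, a hydroxyl or a carboxylic acid here would stay within the scatter remains open. So does whether any group at this position can move the number beyond it.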